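Replacing the Pyridinyl Amide Substituent with Dichlorophenyl

This account rests on a few compounds, and the source may have more. Where it says the series, first, only, none or still open, it means among the compounds named here.

Compound 2 `CO[C@@H]1CC=C2N(c3ccccn3)C(=O)C[C@]2(c2ccccc2)O1` is one of two compounds with a value in a functional assay on SK-BR-3 cells (Homo sapiens) for cytotoxicity, read by sulforhodamine B assay, with a stated time of 48 h; a higher number here means a weaker inhibitor, a lower number a stronger inhibitor. In this assay compound 2 gives 1100 nM. The other measured compound, compound 1 `CO[C@@H]1CC=C2NN(c3ccc([N+](=O)[O-])cc3)C(=O)CC[C@]2(c2ccccc2)O1`, is built on a different core, and in this assay compound 1 gives 7700 nM. The gap between these two values is beyond the scatter, so compound 2 has the lower number of the two, but because the two structures differ in more than one place, no single step can be read from the pair.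

Compound 3 `CO[C@@H]1CC=C2N(c3cc(Cl)cc(Cl)c3)C(=O)C[C@]2(c2ccccc2)O1` has not yet been measured. It differs from compound 2 in one place: 3,5-dichlorophenyl in place of pyridin-2-yl on an amide-type nitrogen in a ring. Among the measured compounds shown here, no measured pair traces this change, so there is no reference step for it. In the absence of such a reference, the change is expected to move the value little, neither clearly up nor clearly down beyond the scatter. In this assay the expected step is a 1.1-fold lower number from compound 2 to compound 3 (0.04 log units; within the scatter). For compound 3 the value is estimated at 1000 nM, with a range from 350 nM to 3000 nM.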

Compound 3, half-maximal inhibitory concentration: 6540 nM
Compound 3: middle estimate off by 6.5-fold (0.82 log units), on the low side; the whole stated range lies below it.
By their numbers in this assay, from the lowest: compound 2; then compounds 3 and 1 (each within the scatter of the next).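

In this assay, among the compounds shown here, the amide-type nitrogen of the shared core proves sensitive to the ring it carries: 3,5-dichlorophenyl in place of pyridin-2-yl gives a 5.9-fold higher number from compound 2 to compound 3 (0.77 log units; beyond the scatter) and is the first step that can be read at this position, since the earlier pair differed in more than one place. The change replaces a six-membered aromatic ring with 1 hetero atom and 1 hydrogen-bond acceptor by a ring of carbon only that bears two chlorines and has 0 hydrogen-bond acceptors, and of these two compounds the one with pyridin-2-yl keeps the lower number. No measurement at hand accounts for the rise in the number that comes with this change.

With a single step at this position, the compounds shown leave open whether the rise goes with the two chlorines, with the loss of the ring nitrogen, or with both, a question that an unsubstituted phenyl on the same nitrogen would help to separate. They also leave open how this position responds to a group without an aromatic ring, such as a methyl or a longer alkyl chain.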